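The compounds below may be only part of what the source reports. "The series", "measured", "known", "first", "only" and "open" are said of these compounds alone.

Measured so far in a functional assay on NB1 cells (Homo sapiens) for cytotoxicity, read by MTT assay, with a stated time of 3 days; on this read-out higher numbers stand for weaker inhibition and lower numbers for stronger inhibition:
- compound 1 `CNc1nc(SCc2nc3ccccc3[nH]2)nc(-c2ccccc2)c1C#N` gives 4.46 nM
- compound 2 `N#Cc1c(NC(N)=O)nc(SCc2nc3ccccc3[nH]2)nc1-c1ccccc1` gives 7.35 nM
- compound 3 `N#Cc1c(-c2ccccc2)nc(SCc2nc3ccccc3[nH]2)nc1N1CCNCC1` gives 6.75 nM

In this assay compound 3 stands at 6.75 nM, within the scatter of both other compounds. The next analogue, compound 4 `Cc1ccc(S(=O)(=O)N2CCN(c3nc(SCc4nc5ccccc5[nH]4)nc(-c4ccccc4)c3C#N)CC2)cc1`, keeps the piperazine ring of compound 3 and carries (4-methylphenyl)sulfonyl in place of hydrogen on an amine nitrogen in a ring.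

Two measured steps change the group on the same aromatic carbon: a 1.5-fold higher number from compound 1 to compound 3 (0.18 log units; within the scatter) and a 1.1-fold lower number from compound 2 to compound 3 (0.04 log units; within the scatter). Both lie within the scatter, as does a 1.6-fold higher number from compound 1 to compound 2 (0.22 log units; within the scatter). None of them places a group on the ring nitrogen, so they bear on this change only indirectly and the range must stay wide. No step beyond the scatter is expected in either direction. The expected change is a 1.2-fold higher number from compound 3 to compound 4 (0.07 log units; within the scatter). For compound 4 the estimated value is 8 nM. The expected range for compound 4 runs from 2.5 nM to 25 nM.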

Compound 4, half-maximal inhibitory concentration: 6.75 nM
Estimate against measurement, compound 4: 1.2-fold (0.07 log units) above; measured number inside the range.
By their numbers in this assay, from the lowest: compounds 1, 3, 4 and 2 (each within the scatter of the next).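

In this assay, going by these compounds alone, this is the first step that places a group on the amine nitrogen of the six-membered ring rather than changing the group on the aromatic carbon, and exchanging hydrogen for (4-methylphenyl)sulfonyl gives no change at the digits printed from compound 3 to compound 4 (within the scatter). Within the data shown here, on this read-out, then, the nitrogen accepts a group of this size, with its carbon-only aromatic ring and sulfonyl, without a step beyond the scatter, which the earlier compounds could not show. Nothing at hand accounts for this result.

Still open, going by these compounds, is whether a methyl, an acetyl or a short chain ending in a carboxylic acid on the same nitrogen would also stay within the scatter of compound 3. Among these compounds, with only one group on this nitrogen, no trend across groups can be read, and how far this tolerance extends remains undefined.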